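The source may hold more compounds than are shown below. What is called first, only, known or untested is meant among the compounds shown, and "the series" means these compounds.

Compound 1 `CCCCCCCCn1cc(/C=C/C(=O)c2ccc(NC(=O)CN3CCN(c4ccccc4F)CC3)cc2)nn1` gives 33800 nM in a functional assay on HeLa cells (Homo sapiens) for inhibition, read by MTT assay; on this read-out lower numbers stand for stronger inhibition and higher numbers for weaker inhibition. Compound 2 `CCCCCCCCn1cc(/C=C/C(=O)c2ccc(NC(=O)CBr)cc2)nn1` gives 8420 nM. Compound 3 `CCCCCCCCn1cc(/C=C/C(=O)c2ccc(N)cc2)nn1` gives 26900 nM.

Among the compounds with values here, compound 3 stands second highest of the three numbers in this assay; compound 1 lies within the scatter of it, while the only measured step, a 3.2-fold higher number from compound 2 to compound 3 (0.50 log units; beyond the scatter), separates it from compound 2. Compound 4 `CCCCCCCCCCn1cc(/C=C/C(=O)c2ccc(N)cc2)nn1` differs from compound 3 by ethyl in place of hydrogen on a saturated chain carbon, eight bonds along the chain from an aromatic nitrogen. Within the data shown here, that step concerns a different part of the molecule from the one change measured so far, so no measured step bears on it, and nothing in these data points to a shift beyond the scatter. Compound 4 is therefore estimated near compound 3, at 27000 nM, with a range of 10000 nM to 75000 nM. The expected step is a 1.0-fold higher number from compound 3 to compound 4 (0.00 log units; within the scatter).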

Compound 4, half-maximal inhibitory concentration: 73600 nM
Compound 4: middle estimate off by 2.7-fold (0.44 log units), on the low side; measured number inside the range.
By their numbers in this assay, from the lowest: compound 2; then compounds 3 and 1 (each within the scatter of the next); then compound 4.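

In this assay, ethyl in place of hydrogen on a saturated chain carbon, eight bonds along the chain from an aromatic nitrogen, gives a 2.7-fold higher number from compound 3 to compound 4 (0.44 log units; beyond the scatter) and so weakens inhibition. Within the data shown here, this is the first measured change in this part of the molecule, and it shows that extending the chain at this position moves the number beyond the scatter. No measurement here explains the step.

As far as these compounds go, whether a longer chain would weaken inhibition further, or a shorter one strengthen it, remains open. So does the effect of a terminal amine or carboxylic acid at this position, or of the same extension on compound 2.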